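A few compounds are considered here, and "the series" means these few. Any claim that something is new, unique, unknown or untested is made for them only; others in the source may bear on it.

Of the compounds shown here, two sharing one core have numbers so far in a functional assay on HT cells (Homo sapiens) for antiproliferative activity, read by fluorescence, with a stated time of 72 h (a lower number here means a stronger inhibitor of growth, a higher number a weaker inhibitor of growth), on record. Compound 1 `CC(C)c1n[nH]c2c(NCc3ccc(-c4ccccn4)cc3)nc(SCC(O)CN3CCNCC3)nc12` gives 332 nM and compound 2 `CC(C)c1n[nH]c2c(NCc3ccc(-c4ccccn4)cc3)nc(SCC(O)CN)nc12` gives 55 nM as the lower of the two. Among the measured compounds shown here, the single measured step of a 6.0-fold lower number from compound 1 to compound 2 (0.78 log units; beyond the scatter) is modest but beyond the scatter, with amino in place of piperazin-1-yl. Compound 3 `CC(C)c1n[nH]c2c(NCc3ccc(-c4ccccn4)cc3)nc(SCCCN(C)C)nc12` alters the same side chain again, as 2-(dimethylamino)ethyl in place of 2-amino-1-hydroxyethyl on a saturated chain carbon bound to a sulfur shows, with 2-(dimethylamino)ethyl in place of 2-amino-1-hydroxyethyl on a saturated chain carbon bound to a sulfur. For the measured compounds named here, no measured step isolates this change, so the step of a 6.0-fold lower number from compound 1 to compound 2 (0.78 log units; beyond the scatter) bears on it only as a sign that the end of this chain can shift the number in this assay by that order. A moderately higher number is expected, and the estimated step of a 2.4-fold higher number from compound 2 to compound 3 (0.37 log units; beyond the scatter) is smaller than that one. For compound 3 the estimated value is 130 nM with 40 nM to 400 nM as the expected range.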

Compound 3, concentration for 50% growth inhibition: 105 nM
Estimate against measurement, compound 3: 1.2-fold (0.09 log units) above; the range from low to high includes it.
By their numbers in this assay, from the lowest: compounds 2 and 3 (each within the scatter of the next); then compound 1.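

In this assay, replacing 2-amino-1-hydroxyethyl with 2-(dimethylamino)ethyl gives a 1.9-fold higher number from compound 2 to compound 3 (0.28 log units; within the scatter), so this position accepts the loss of the chain hydroxyl and the change at the amine together without a difference this read-out can separate. The same group set against 1-hydroxy-2-(piperazin-1-yl)ethyl gives a 3.2-fold lower number from compound 1 to compound 3 (0.50 log units; beyond the scatter), so among the three compounds, both open-chain amine ends give lower numbers than the piperazin-1-yl end. No available evidence accounts for either step.

The hydroxyl and the amine change arrive together in compound 3, and a 3-aminopropyl or a 3-(dimethylamino)-2-hydroxypropyl group on the sulfur would be needed to read them apart. On these data alone, it also remains open how the number would respond to a longer chain or to a chain end with no amine, such as a carboxylic acid.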